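The source may hold more compounds than are shown below. What is called first, only, known or untested is meant among the compounds shown, and "the series" means these compounds.

Working notes on the series. Of the compounds shown here, three carrying the shared core have been measured in an assay on HEK293 cells for agonist activity at transient receptor potential cation channel subfamily M member 8 (Homo sapiens), read by fluorescence and calcium flux, with a stated time of 15 min; on this read-out higher numbers stand for an effect only at larger amounts of compound and lower numbers for an effect already at smaller amounts. Compound 1 `CCN(Cc1cccn1C)C(=O)COc1ccc(C)cc1` gives 21300 nM in this assay, the highest number of the three. Compound 3 `CCN(Cc1cccs1)C(=O)COc1ccc(C#N)cc1` gives 1990 nM, the nearest to compound 1, and compound 2 `Cc1ccc(OCC(=O)N(Cc2cccs2)c2ccn(C)n2)cc1` gives 855 nM, the furthest from it; both gaps lie beyond the usual scatter, so compound 1 shows the weakest effect of the set. Among the measured compounds shown here, no two measured compounds differ in a single place, so no isolated step is available from the measurements.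

Compound 4 `CCN(Cc1cccnc1)C(=O)COc1ccc(C)cc1` differs from compound 1 in one place: pyridin-3-yl in place of 1-methyl-1H-pyrrol-2-yl on a saturated chain carbon bound to an amide-type nitrogen. For the measured compounds named here, no measured pair shows this change, and nothing in the set carries a pyridin-3-yl group, so the expectation rests on compound 1 alone and on the general observation that the measured numbers vary widely with the group on the amide-type nitrogen. For compound 4 the expected step is a 1.4-fold lower number from compound 1 to compound 4 (0.15 log units; within the scatter), in the direction of a slightly lower number but not clearly beyond the scatter. Compound 4 is estimated to give about 15000 nM in this assay, with a range from 4000 nM to 60000 nM, and a fair chance that only a limit is reported given how weak compound 1 is.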

Compound 4, half-maximal effective concentration: 15400 nM
Estimate against measurement, compound 4: 1.0-fold (0.01 log units) below; measured number inside the range.
By their numbers in this assay, from the lowest: compound 2; then compound 3; then compounds 4 and 1 (each within the scatter of the next).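

Pyridin-3-yl in place of 1-methyl-1H-pyrrol-2-yl, on a saturated chain carbon bound to an amide-type nitrogen, provides the first isolated step of the series: in this assay, the result is a 1.4-fold lower number from compound 1 to compound 4 (0.14 log units; within the scatter). At this place, therefore, a six-membered aromatic ring with 1 hetero atom and a five-membered aromatic ring with 1 hetero atom cannot be told apart on this read-out, at least with the rest of compound 1 held constant. No available data bear on why the two groups read alike.

This single pair does not show whether the same holds for other groups at this place, such as a plain phenyl ring, a pyridine carrying a carboxylic acid, or a basic amine on a longer chain. It also leaves open whether pyridin-3-yl would read the same way when the other parts of the shared core are changed, since only one background has been tested for this change.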